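A few compounds are considered here, and "the series" means these few. Any claim that something is new, unique, unknown or untested is made for them only; others in the source may bear on it.

Compound 1 `CONC(=S)N/N=C1\C(=O)N(CN(C)C)c2ccc(F)cc21`: 560000 nM
Compound 2 `Cc1ccc2c(c1)/C(=N/NC(=S)NO)C(=O)N2CN(C)C`: 651000 nM
Compound 3 `CONC(=S)N/N=C1\C(=O)N(CN2CCN(c3ccc(Cl)cc3)CC2)c2ccc(C)cc21`: 300000 nM

All three compounds were tested in an ADME assay on MT4 cells (Homo sapiens) for cytotoxicity, read by spectrophotometry, with a stated time of 5 days; on this read-out lower numbers stand for higher toxicity in this test and higher numbers for lower toxicity in this test. Compound 2 gives 651000 nM and sits at the top of this small set of numbers, but it cannot be separated from compound 1, as the two values lie within the scatter of each other. Only compound 3 stands clearly apart from compound 2, with a lower number beyond the scatter.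

The next compound to be tested is compound 4 `CN(C)CN1C(=O)/C(=N\NC(=S)NO)c2cc(F)ccc21`, which carries fluoro in place of methyl on an aromatic carbon relative to compound 2 (fluoro in place of methyl on an aromatic carbon). Among the measured compounds shown here, the measured compounds include no pair that differs in one place only, so nothing shows the effect of this change directly. One indirect hint is that compound 1, which also carries a fluoro group, gives 560000 nM, a number within the scatter of compound 2. No step beyond the scatter is therefore expected in this assay. The expected change is small, with an estimated 1.2-fold lower number from compound 2 to compound 4 (0.07 log units; within the scatter). For compound 4 the estimated value is 550000 nM, with an expected range of 280000 nM to 1000000 nM.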

Compound 4, half-maximal cytotoxic concentration: 599000 nM
For compound 4 the middle estimate is 1.1-fold (0.04 log units) below the measured one; the range from low to high includes it.
By their numbers in this assay, from the lowest: compounds 3, 1, 4 and 2 (each within the scatter of the next, the first and the last beyond it).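

In this assay, compound 4 gives the first direct read of this position, on an aromatic carbon of a six-membered aromatic ring of carbon only: fluoro in place of methyl gives a 1.1-fold lower number from compound 2 to compound 4 (0.04 log units; within the scatter), so this exchange cannot be told apart from the usual spread of repeated measurements. It also links compound 4 to compound 1 through a second change in one place, hydrogen in place of methyl on an oxygen, which gives a 1.1-fold higher number from compound 1 to compound 4 (0.03 log units; within the scatter) and likewise stays inside that spread, so neither of the two single changes shown here separates its pair of compounds in this test. Nothing available bears on why the numbers of these pairs stay so close.

From the compounds shown here alone, whether another group on the same aromatic carbon, such as chloro, methoxy or a carboxylic acid, or a longer chain such as ethyl on the oxygen, would give a step beyond the scatter remains open. Compound 3 differs from each of the other compounds in more than one place, so its number cannot be tied to any single group.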